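The source may report more compounds than this note shows. Statements on the series, on what has been measured and on what is new or still open speak of the compounds shown alone.

Series notes. Among the compounds with values here, compound 2 `C[C@@H](O[C@H]1CN2C(=O)C=C(c3cc[nH]c(=O)c3)CC2[C@@H]1c1ccc(F)cc1)c1cc(C(F)(F)F)cc(C(F)(F)F)c1` gives 0.27 nM in an assay on CHO cells for displacement of a labelled ligand from Substance-P receptor (Homo sapiens) (on this read-out higher numbers stand for weaker inhibition and lower numbers for stronger inhibition), the lowest of the two numbers measured so far; compound 1 `C[C@@H](O[C@H]1CN2C(=O)C=C(c3ccc(F)cc3)CC2[C@@H]1c1ccc(F)cc1)c1cc(C(F)(F)F)cc(C(F)(F)F)c1` gives 2 nM. Within the data shown here, the only measured step, a 7.4-fold lower number from compound 1 to compound 2 (0.87 log units; beyond the scatter), bears on the next change in that it also swaps the group on the double-bonded ring carbon. Compound 3 `CCc1noc(C2=CC(=O)N3C[C@H](O[C@H](C)c4cc(C(F)(F)F)cc(C(F)(F)F)c4)[C@@H](c4ccc(F)cc4)C3C2)n1` carries a group of 7 heavy atoms (4 carbon, 2 nitrogen, 1 oxygen; one five-membered aromatic ring with 3 hetero atoms) in place of a group of 7 heavy atoms (5 carbon, 1 nitrogen, 1 oxygen; one six-membered aromatic ring with 1 hetero atom), on a double-bonded ring carbon. That step brings in a ring that was not tested before, and the pyridinone's hydrogen-bond donor leaves, so the gain seen in compound 2 is expected to be partly given back. Compound 3 is therefore estimated at 1 nM in this assay, range 0.2 nM to 5 nM, meaning a 3.7-fold higher number from compound 2 to compound 3 (0.57 log units; beyond the scatter).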

Compound 3, half-maximal inhibitory concentration: 0.4 nM
The estimate for compound 3 lay 2.5-fold (0.40 log units) above the measured number, within the range that was stated.
By their numbers in this assay, from the lowest: compounds 2 and 3 (each within the scatter of the next); then compound 1.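

In this assay, 3-ethyl-1,2,4-oxadiazol-5-yl on the double-bonded ring carbon gives a 1.5-fold higher number from compound 2 to compound 3 (0.17 log units; within the scatter), so a five-membered aromatic ring with 0 hydrogen-bond donors holds the level of the six-membered ring in compound 2, which has 1 hydrogen-bond donor. Set against 4-fluorophenyl, the same group gives a 5.0-fold lower number from compound 1 to compound 3 (0.70 log units; beyond the scatter), so the gain over compound 1 at this position does not require a hydrogen-bond donor in the entering group. No measurement here gives a reason for either step.

Going by these compounds, it remains open whether the ethyl chain on the oxadiazole ring matters, and how a methyl group, a longer chain or an amine in its place would read.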